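This account rests on a few compounds, and the source may have more. Where it says the series, first, only, none or still open, it means among the compounds named here.

In an assay on microsomes from liver for inhibition of 3-hydroxy-3-methylglutaryl-coenzyme A reductase (Rattus norvegicus) (a lower number here means a stronger inhibitor, a higher number a weaker inhibitor), compound 1 `COc1cccc(-c2nc(C(F)(F)F)n(CC[C@@H](O)C[C@@H](O)CC(=O)O)c2-c2ccc(F)cc2)c1` gives 20 nM. Compound 2 `Cc1nc(-c2ccc(F)cc2)c(-c2ccc(F)cc2)n1/C=C/[C@@H](O)C[C@@H](O)CC(=O)O` reaches only a limit of that assay, > 100 nM. This is the limit of > 100 nM in this assay, at which 1 of the 2 values shown sits. Compound 3 `CC(C)(C)c1nc(-c2ccc(F)cc2)c(-c2ccc(F)cc2)n1/C=C/[C@@H](O)C[C@@H](O)CC(=O)O` differs from compound 2 in one place: tert-butyl in place of methyl on an aromatic carbon, a tert-butyl in place of methyl on an aromatic carbon. Among the compounds with values here, no measured pair shows what this change does, so from compound 2 to compound 3 a step that the limit leaves unreadable from compound 2 to compound 3 is expected, in no particular direction beyond the usual scatter. Compound 3 is estimated at 150 nM, with a range from 30 nM to 800 nM.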

Compound 3, half-maximal inhibitory concentration: 7 nM
The estimate for compound 3 lay 21-fold (1.33 log units) above the measured number; measured number below the stated range.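

In this assay, the carbon between two ring nitrogen atoms accepts a much larger group than methyl without any loss: tert-butyl in place of methyl gives an at least 14-fold lower number from compound 2 to compound 3 (1.15 log units; beyond the scatter). This position therefore matters for inhibition, and here the larger of the two groups gives the stronger inhibitor. The comparison has one open end, since compound 2 stands at a limit of the assay and not at a number: the limit of > 100 nM in this assay, at which 1 of the 3 values shown sits.

Only methyl and tert-butyl are shown at this carbon, so the effect of an isopropyl group, a phenyl ring or an amine there remains open. As far as these compounds go, whether tert-butyl gives the same gain on other cores also remains open.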